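Sulfonamide series: replacing fluoro with tert-butyl

The source may report more compounds than this note shows. Statements on the series, on what has been measured and on what is new or still open speak of the compounds shown alone.

Values in a functional assay on HT-29 cells (Homo sapiens) for antiproliferative activity, read by sulforhodamine B assay, with a stated time of 48 h (a higher number here means a weaker inhibitor, a lower number a stronger inhibitor), so far
- compound 1 `O=C1NCCN1c1ccc(S(=O)(=O)Nc2ccc3[nH]ccc3c2)cc1` gives 130 nM
- compound 2 `Cc1cccc(NS(=O)(=O)c2ccc(N3CCNC3=O)cc2)c1` gives 110 nM
- compound 3 `O=C1NCCN1c1ccc(S(=O)(=O)Nc2ccc(F)cc2)cc1` gives 370 nM

Compound 3 stands highest of the three at 370 nM and its gaps to compound 1 and compound 2 both lie beyond the scatter. Compound 4 `CC(C)(C)c1ccc(NS(=O)(=O)c2ccc(N3CCNC3=O)cc2)cc1` is still unmeasured. It carries tert-butyl in place of fluoro on an aromatic carbon, para to a large group (tert-butyl in place of fluoro on an aromatic carbon) and otherwise matches compound 3. For the measured compounds named here, only one measured step ends on the fluoro compound. Read backwards, a 3.4-fold higher number from compound 2 to compound 3 (0.53 log units; beyond the scatter) suggests that leaving fluoro may lower the number, although no measured compound carries tert-butyl and the support is thin. The expected change is a 2.2-fold lower number from compound 3 to compound 4 (0.34 log units; beyond the scatter) in this assay and it should stay modest. Compound 4 is estimated at 170 nM with an expected range from 50 nM to 600 nM for this measurement.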

Compound 4, half-maximal inhibitory concentration: > 1000 nM
Compound 4: a limit, no number; the forecaster's own chance of this, stated with the estimate: 3%; at least 5.8-fold (0.76 log units) between middle value and limit.
By their numbers in this assay, from the lowest: compounds 2 and 1 (each within the scatter of the next); then compound 3. At a limit, above all of these: compound 4.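

In this assay compound 4 gives > 1000 nM, which is a limit of the assay and not a number. Tert-butyl in place of fluoro on an aromatic carbon, para to a large group, gives an at least 2.7-fold higher number from compound 3 to compound 4 (0.43 log units; beyond the scatter), the first sign in the series that leaving fluoro at this position can raise the number, since the only earlier step ending on the fluoro compound gave no reading of a change here. The step has a floor and no measured size, so how far tert-butyl raises the number stays unknown: the limit of > 1000 nM in this assay, at which 1 of the 4 values shown sits.

The compounds shown leave open how an amine, a methoxy group or a carboxylic acid would read at this position. For the compounds shown here, with only one tert-butyl compound, they also cannot say whether tert-butyl elsewhere on that ring would read the same way.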